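Replacing 5-cyanothiophen-2-yl with pyrimidin-5-yl

This account rests on a few compounds, and the source may have more. Where it says the series, first, only, none or still open, it means among the compounds named here.

Three related compounds have been tested so far in a physicochemical assay for solubility, in phosphate buffer, with a stated time of 18 h, at pH 7; on this read-out lower numbers stand for lower solubility and higher numbers for higher solubility. Compound 1 (`CC(=O)N1CCCC([C@@H]2[C@@H](C(=O)Nc3ccc(F)c(C#N)c3)c3ccccc3C(=O)N2CC(C)C)C1`), which carries 1-acetylpiperidin-3-yl on a saturated ring carbon, gives 69000 nM. Compound 2 (`Cc1ccc([C@@H]2[C@@H](C(=O)Nc3ccc(F)c(C#N)c3)c3ccccc3C(=O)N2CC(C)C)s1`), with 5-methylthiophen-2-yl at that carbon, gives < 1000 nM, which is a limit of the assay and not a number. Compound 3 (`CC(C)CN1C(=O)c2ccccc2[C@H](C(=O)Nc2ccc(F)c(C#N)c2)[C@H]1c1ccc(C#N)s1`), with 5-cyanothiophen-2-yl there, gives 4900 nM, the lower of the two true numbers. For the measured compounds named here, the only other true number lies well above it, since the data show a 14-fold lower number from compound 1 to compound 3 (1.15 log units; beyond the scatter).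

Compound 4 (`CC(C)CN1C(=O)c2ccccc2[C@H](C(=O)Nc2ccc(F)c(C#N)c2)[C@H]1c1cncnc1`) has pyrimidin-5-yl in place of 5-cyanothiophen-2-yl on that saturated ring carbon: pyrimidin-5-yl in place of 5-cyanothiophen-2-yl on a saturated ring carbon. Going by the values given here, no tested compound carries this group, so no measured step matches the change exactly. Three steps offer guidance. Leaving 1-acetylpiperidin-3-yl for a thiophene group was large both ways, with an at least 69-fold lower number from compound 1 to compound 2 (1.83 log units; beyond the scatter) alongside the step to compound 3. On the thiophene itself, the data show an at least 4.9-fold higher number from compound 2 to compound 3 (0.69 log units; beyond the scatter). Both thiophene compounds therefore sit low in this assay, and removing that group may win back part of the gap to compound 1. A moderate rise is expected, seen as a 4.5-fold higher number from compound 3 to compound 4 (0.65 log units; beyond the scatter). For compound 4 the estimated value is 22000 nM, with an expected range of 6000 nM to 80000 nM.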

Compound 4, solubility: 54000 nM
Compound 4: middle estimate off by 2.5-fold (0.39 log units), on the low side, and the stated range covers the measured number.
By their numbers in this assay, from the lowest: compound 3; then compounds 4 and 1 (each within the scatter of the next). At a limit, below all of these: compound 2.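

In this assay, the two thiophene compounds left it unclear whether any aromatic group at this saturated ring carbon keeps the number low, and pyrimidin-5-yl shows that this need not be so, with an 11-fold higher number from compound 3 to compound 4 (1.04 log units; beyond the scatter). Set against the group that is not aromatic, the result is a 1.3-fold lower number from compound 1 to compound 4 (0.11 log units; within the scatter), so in this assay leaving 1-acetylpiperidin-3-yl for pyrimidin-5-yl makes no measurable difference. Against 5-methylthiophen-2-yl the result is an at least 54-fold higher number from compound 2 to compound 4 (1.73 log units; beyond the scatter), and that size is only a bound, since compound 2 stands at a limit of the assay and not at a number: the limit of < 1000 nM in this assay, at which 1 of the 4 values shown sits.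

The compounds shown leave open whether the large step follows from the change of ring size, from the ring nitrogens or from the loss of the thiophene sulfur, as all three change together between compound 3 and compound 4. A plain phenyl or a pyridin-3-yl group at this carbon would help to pull these apart, and an amine on the pyrimidine would show whether this ring tolerates further substitution in this assay.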